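A Ring Replaces the Amide on the Shared Core

This account rests on a few compounds, and the source may have more. Where it says the series, first, only, none or still open, it means among the compounds named here.

Compound 2 `COc1ccc(-c2nc(C(=O)N(C)C)sc2-c2ccc(OC)cc2)cc1` carries a dimethylcarbamoyl group on the shared core. In a functional assay with Oryctolagus cuniculus as the target (on this read-out higher numbers stand for weaker inhibition and lower numbers for stronger inhibition), compound 2 gives < 100 nM, which is a limit of the assay and not a number. Compound 1 `COc1ccc(-c2nc(/N=C(\N)n3ccnc3)sc2-c2ccc(OC)cc2)cc1` bears in the same place a group of 8 heavy atoms. In this assay compound 1 gives > 100 nM, again a limit rather than a number. Within the data shown here, the single measured step, a number no higher from compound 1 to compound 2 (the limit leaves the size open), is therefore readable only in its direction, resting on the limit of < 100 nM in this assay, at which 1 of the 2 values shown sits, and (the limit of > 100 nM in this assay, at which 1 of the 2 values shown sits). Compound 3 `COc1ccc(-c2nc(C3=NNC(=O)CC3)sc2-c2ccc(OC)cc2)cc1` is not yet measured. It differs from compound 2 in one place: a group of 7 heavy atoms (4 carbon, 2 nitrogen, 1 oxygen; one six-membered non-aromatic ring with 2 hetero atoms) in place of a group of 5 heavy atoms (3 carbon, 1 nitrogen, 1 oxygen; no ring), on an aromatic carbon. Among the measured compounds shown here, no measured step trades a dimethylcarbamoyl group for a six-membered non-aromatic ring of this kind, so the measured steps give no size for the change, and the step from compound 1 to compound 2 only shows that the position tolerates exchange. Compound 3 is accordingly expected to land close to where compound 2 stands. The expected step is a step that the limit leaves unreadable from compound 2 to compound 3. The estimate for compound 3 in this assay is 80 nM, with a range from 20 nM to 400 nM.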

Compound 3, half-maximal inhibitory concentration: > 1000 nM
Compound 3: a limit, no number; the forecaster's own chance of this, stated with the estimate: 50%; middle value at least 12-fold (1.09 log units) away from the limit.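

In this assay compound 3 gives > 1000 nM, which is a limit of the assay and not a number. Putting the six-membered non-aromatic ring with 2 hetero atoms in place of the dimethylcarbamoyl group gives an at least 10-fold higher number from compound 2 to compound 3 (1.00 log units; beyond the scatter), so this aromatic carbon of the shared core does not tolerate every exchange, and the change carries a size that can be told apart from the scatter. The earlier pair could show only a direction, and the step between compound 1 and compound 3 cannot be read, as both of its values are limits.

On these data alone, what remains open is which difference between the two groups matters, since the ring, the added hydrogen-bond donor and the larger heavy-atom count all enter together in this one step. Also open, as far as these compounds go, are how strong compound 2 really is, and whether a primary carboxamide, a carboxylic acid or a longer open-chain amide on the same carbon would stay close to the dimethylcarbamoyl group or fall away as the ring does.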